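From amide to urea on a sulfonate ester scaffold

The source may hold more compounds than are shown below. What is called first, only, known or untested is meant among the compounds shown, and "the series" means these compounds.

Three aryl sulfonate esters have been measured in a functional assay on HT-1080 cells (Homo sapiens) for antiproliferative activity, read by sulforhodamine B assay, with a stated time of 48 h; a lower number here means a stronger inhibitor, a higher number a weaker inhibitor. Compound 1 `CC(C)c1ccccc1OS(=O)(=O)c1cccc(NC(=O)CCl)c1` gives 780 nM, and compound 2 `CCC(=O)Nc1ccc(S(=O)(=O)Oc2ccccc2C(C)C)cc1` gives 2100 nM. Compound 3 `CCC(=O)Nc1ccc(S(=O)(=O)Oc2ccccc2I)cc1` gives 7200 nM, the highest of the three numbers. Among the compounds with values here, the only measured single change, a 3.4-fold higher number from compound 2 to compound 3 (0.54 log units; beyond the scatter), arises from iodo in place of isopropyl on an aromatic carbon. Compound 4 `O=C(NCCCCl)Nc1ccc(S(=O)(=O)Oc2ccccc2I)cc1` differs from compound 3 elsewhere: (3-chloropropyl)amino in place of ethyl on a carbonyl carbon. Within the data shown here, no measured step touches the carbonyl carbon, so nothing in the set bears on this change, and the expectation rests on compound 3 alone. Compound 4 is expected to show a step of a 1.2-fold lower number from compound 3 to compound 4 (0.08 log units; within the scatter), not beyond the scatter in this assay. The estimate for compound 4 is 6000 nM, within 1500 nM to 25000 nM.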

Compound 4, half-maximal inhibitory concentration: 2800 nM
The estimate for compound 4 lay 2.1-fold (0.33 log units) above the measured number, within the range that was stated.
By their numbers in this assay, from the lowest: compound 1; then compounds 2 and 4 (each within the scatter of the next); then compound 3.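

In this assay, within the data shown here, this is the first measured change at the carbonyl carbon: (3-chloropropyl)amino in place of ethyl gives a 2.6-fold lower number from compound 3 to compound 4 (0.41 log units; beyond the scatter) and the step is beyond the scatter. The position therefore accepts the larger group, which turns the amide-type nitrogen's carbonyl into a urea, with no loss and a modest gain. Nothing available here accounts for this gain. Going by these compounds, the step adds the nitrogen and the chlorine together, so their separate shares remain open. A plain propylamino group or a longer chloroalkyl chain would be needed to separate them.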